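Amide aryl swaps in a flavonol series

This account rests on a few compounds, and the source may have more. Where it says the series, first, only, none or still open, it means among the compounds named here.

Three compounds share one core and differ only in the aryl group on the amide carbonyl carbon. Compound 1 `O=C(Nc1cccc(-c2oc3cc(-c4ccc(F)cc4)ccc3c(=O)c2O)c1)c1ccc(Cl)cc1` gives 12800 nM in a functional assay on MDA-MB-231 cells (Homo sapiens) for antiproliferative activity, read by CCK-8 assay, with a stated time of 72 h; on this read-out lower numbers stand for stronger inhibition and higher numbers for weaker inhibition. Compound 2 `O=C(Nc1cccc(-c2oc3cc(-c4ccc(F)cc4)ccc3c(=O)c2O)c1)c1ccc(F)cc1F` gives 11200 nM in this assay, and compound 3 `Cc1cc(C(=O)Nc2cccc(-c3oc4cc(-c5ccc(F)cc5)ccc4c(=O)c3O)c2)ccc1F` gives 7440 nM. Compound 2 sits with its nearest neighbour compound 1, since a 1.1-fold lower number from compound 1 to compound 2 (0.06 log units; within the scatter); its furthest neighbour is compound 3, since a 1.5-fold lower number from compound 2 to compound 3 (0.18 log units; within the scatter), and also a 1.7-fold lower number from compound 1 to compound 3 (0.24 log units; within the scatter). All three numbers lie within the scatter of one another.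

Compound 4 `N#Cc1ccc(C(=O)Nc2cccc(-c3oc4cc(-c5ccc(F)cc5)ccc4c(=O)c3O)c2)cc1` carries the change (4-cyanophenyl in place of 2,4-difluorophenyl on a carbonyl carbon). Every measured step in this set is of the same kind, an exchange of the aryl group on the carbonyl carbon, and none of them moved the number beyond the scatter. On that basis the step from compound 2 to compound 4 is expected to be a 1.0-fold lower number from compound 2 to compound 4 (0.01 log units; within the scatter), that is, no shift beyond the scatter in this assay. Compound 4 is therefore estimated at 11000 nM, with a range from 5000 nM to 25000 nM.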

Compound 4, half-maximal inhibitory concentration: 11600 nM
The estimate for compound 4 lay 1.1-fold (0.02 log units) below the measured number, within the range that was stated.
By their numbers in this assay, from the lowest: compounds 3, 2, 4 and 1 (each within the scatter of the next).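

In this assay the 4-cyanophenyl group on the carbonyl carbon adds a triple bond and one hydrogen-bond acceptor where 2,4-difluorophenyl has none, yet the steps read a 1.0-fold higher number from compound 2 to compound 4 (0.02 log units; within the scatter) and a 1.6-fold higher number from compound 3 to compound 4 (0.19 log units; within the scatter) and a 1.1-fold lower number from compound 1 to compound 4 (0.04 log units; within the scatter) and so stay flat. Among these compounds, this position therefore accepts a nitrile on the aryl group, as well as the halogen and methyl patterns of compounds 1, 2 and 3, with no step among the four compounds beyond the scatter. No supporting data bear on why the number stays in place here.

Among the compounds shown here, every group at this position so far is a substituted phenyl, so the effect of an amine, a carboxylic acid or a longer alkyl chain on the 4-position of that ring stays open. The shared core is also constant throughout, which leaves open whether any change there would move the number beyond the scatter.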